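Replacing a heptyl chain by a fluorophenyl group

The source may hold more compounds than are shown below. What is called first, only, known or untested is meant among the compounds shown, and "the series" means these compounds.

Measured so far:
- compound 1, `CCCCCCCc1cn(C(c2ccccc2)c2cc3cc(Br)ccc3nc2OC)nn1`: 0.17%
- compound 2, `COc1nc2ccc(Br)cc2cc1C(c1ccccc1)n1cc(-c2ccccc2F)nn1`: 3.97%
- compound 3, `COc1nc2ccc(Br)cc2cc1C(c1ccccc1)n1cc(-c2ccc(OC(F)(F)F)cc2)nn1`: 5.8%

All three were tested in an ADME assay on HEK293 cells (Homo sapiens) for cytotoxicity, read by sulforhodamine B assay, with a stated time of 48 h, tested at 10 uM; a higher number here means more inhibition at the concentration tested (going by the name of the read-out), a lower number less inhibition. Compound 1 stands at the low end of the three numbers, separated from compound 2 by a number 3.8 percentage points higher from compound 1 to compound 2 (within the scatter) and from compound 3 by a number 5.6 percentage points higher from compound 1 to compound 3 (within the scatter), both steps within the scatter. Compound 4, `COc1nc2ccc(Br)cc2cc1C(c1ccccc1)n1cc(-c2ccc(F)cc2)nn1`, differs from compound 1 in one place: 4-fluorophenyl in place of heptyl on an aromatic carbon. The steps from compound 1 to compound 2 and to compound 3, each putting an aryl group where the heptyl chain sat, bear on this change, and neither moved the number beyond the scatter. No step beyond the scatter is therefore expected in this assay; the estimated step is a number 3.8 percentage points higher from compound 1 to compound 4 (within the scatter). Compound 4 is expected to give 4%, in the range -5% to 13%.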

Compound 4, a percentage reported as inhibition, at one concentration (the size of the read-out at that concentration, not a potency): 4.04%
Compound 4: middle estimate off by 0 percentage points, on the low side, and the stated range covers the measured number.
By their numbers in this assay, from the lowest: compounds 1, 2, 4 and 3 (each within the scatter of the next).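

In this assay, 4-fluorophenyl in place of heptyl gives a number 3.9 percentage points higher from compound 1 to compound 4 (within the scatter) and so becomes the third aryl group on this aromatic carbon to stay within the scatter of the heptyl compound. Among the aryl groups, 4-fluorophenyl in place of 2-fluorophenyl gives a number 0.1 percentage points higher from compound 2 to compound 4 (within the scatter) and fluoro in place of trifluoromethoxy gives a number 1.8 percentage points lower from compound 3 to compound 4 (within the scatter) and so these substituents on the phenyl ring do not separate the compounds here. No measurement shown explains these numbers. On these data alone, whether an amine, a carboxylic acid or a shorter chain at this position would give a step beyond the scatter remains open.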